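A few compounds are considered here, and "the series" means these few. Any claim that something is new, unique, unknown or untested is made for them only; others in the source may bear on it.

The study rests on one shared core, shown here as compound 1 `Cc1nnsc1CO/N=C/c1c(C)nn(C)c1Oc1cccc(F)c1`. In a functional assay on PANC-1 cells (Homo sapiens) for inhibition, read by MTT assay, with a stated time of 48 h (a lower number here means a stronger inhibitor, a higher number a weaker inhibitor), compound 1 gives > 50000 nM, which is a limit of the assay and not a number. Compound 2 `Cc1nnsc1CO/N=C/c1c(C)nn(C)c1Oc1cccc(C(F)(F)F)c1` carries trifluoromethyl in place of fluoro on an aromatic carbon, and in this assay compound 2 gives > 50000 nM, again a limit. Compound 3 `Cc1nnsc1CO/N=C/c1c(C)nn(C)c1Oc1cc(F)cc(F)c1` carries fluoro in place of hydrogen on an aromatic carbon, and in this assay compound 3 gives > 50000 nM, also a limit. The step that the two limits leave unreadable from compound 1 to compound 2 and the step that the two limits leave unreadable from compound 1 to compound 3 are both unreadable in size because of the limit of > 50000 nM in this assay, at which 3 of the 3 values shown sit.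

Compound 4 `Cc1nnsc1CO/N=C/c1c(C)nn(C)c1Cl` differs from compound 1 by chloro in place of 3-fluorophenoxy on an aromatic carbon. Neither measured step bears directly on this change, as both alter a substituent on the phenoxy ring rather than replacing that ring with chloro, and neither yields a readable size or direction. What the measured compounds do show is that every variant of this core so far sits at the same limit in this assay. On that basis compound 4 is expected to give about 50000 nM, with a range from 10000 nM to 200000 nM. The step of a number no higher from compound 1 to compound 4 (the limit leaves the size open) is accordingly expected to be essentially none beyond the scatter, with a fair chance that the assay again reports only a limit.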

Compound 4, half-maximal inhibitory concentration: 26600 nM
Compound 4: the middle estimate sits 1.9-fold (0.27 log units) above what was measured; measured number inside the range.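

Compound 4 is the only one of the compounds shown that gives a number rather than a limit in this assay, which makes this position on the five-membered aromatic ring with 2 nitrogen the one place where a change can so far be given any size. Chloro in place of 3-fluorophenoxy is read as an at least 1.8-fold lower number from compound 1 to compound 4 (0.27 log units; that floor lies within the scatter), so the 3-fluorophenoxy group, with its six-membered aromatic ring, is not needed for a measured number in this assay, although the floor alone does not establish a real gain. The true size of this step cannot be read, and neither can the steps among the phenoxy variants, because their values are held at a limit: the limit of > 50000 nM in this assay, at which 3 of the 4 values shown sit.

The compounds shown leave open whether the number of compound 4 belongs to chloro itself or only to the absence of the 3-fluorophenoxy group, a question that an amine, a methoxy group or bromo at this position would bear on. Also open, from the compounds shown here alone, is whether a longer chain in place of the methyl group would shift the number of compound 4 in this assay.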